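The compounds below may be only part of what the source reports. "The series", "measured", "known", "first", "only" and "open" are said of these compounds alone.

Compound 1 `N[C@@H](CO)[C@H](O)/C=C/CCCCCCCCCCc1ccc(I)cc1`: 4380 nM
Compound 2 `N[C@@H](CO)[C@H](O)/C=C/CCCCCCCCCCCc1ccc(I)cc1`: 13300 nM
Compound 3 `N[C@@H](CO)[C@H](O)/C=C/CCCCCCCCCCCCCc1ccc(I)cc1`: not yet measured

In an assay on isolated protein for inhibition of sphingosine kinase 2 (Homo sapiens) (on this read-out lower numbers stand for stronger inhibition and higher numbers for weaker inhibition), compound 2 gives the highest of the two numbers recorded, compound 1 giving the lower one. The step of a 3.0-fold higher number from compound 1 to compound 2 (0.48 log units; beyond the scatter) is modest but beyond the scatter. Compound 3 carries a group of 9 heavy atoms (8 carbon, 1 iodine; one six-membered aromatic ring of carbon only) in place of a group of 7 heavy atoms (6 carbon, 1 iodine; one six-membered aromatic ring of carbon only), on a saturated chain carbon, ten or more bonds along the chain from a double-bonded chain carbon, a further lengthening in the same sense as that step, so a further weakening is expected, plausibly somewhat larger since two chain carbons enter. Compound 3 is therefore expected near 35000 nM, between 12000 nM and 100000 nM, corresponding to an expected step of a 2.6-fold higher number from compound 2 to compound 3 (0.42 log units; beyond the scatter).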

Compound 3, half-maximal inhibitory concentration: 29200 nM
The estimate for compound 3 lay 1.2-fold (0.08 log units) above the measured number; low and high end bracket the measured number.
By their numbers in this assay, from the lowest: compound 1; then compound 2; then compound 3.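

With a group of 9 heavy atoms entering on a saturated chain carbon, this assay shows a 2.2-fold higher number from compound 2 to compound 3 (0.34 log units; beyond the scatter). The weakening therefore persists over a second lengthening, and the numbers rise from compound 1 through compound 2 to compound 3, with none of the three going against this order. No available evidence accounts for this rise. Going by these compounds, whether a shorter chain would give a lower number remains open, as does the effect of a carboxylic acid in place of the 4-iodophenyl.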